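From compound 2 to compound 3: one group rearranged

The source may report more compounds than this note shows. Statements on the series, on what has been measured and on what is new or still open speak of the compounds shown alone.

- compound 1 `Cc1oc(-c2ccccc2Cl)nc1CN1CCC(C(=O)NCCCN2C[C@H](C)C[C@H](C)C2)CC1` gives > 72 ug/mL as a limit
- compound 2 `Cc1ccccc1-c1nc(CN2CCC(C(=O)NCCCN3CCC(C(C)C)CC3)CC2)c(C)o1` gives > 71 ug/mL as a limit

Both entries come from a physicochemical assay for solubility, in phosphate buffer, measured as kinetic solubility, at pH 7.4 (a higher number here means a more soluble compound, a lower number a less soluble compound), and each is a limit of the assay, not a number. Compound 2 stands at > 71 ug/mL as a limit, so no exact figure is available for it. The same holds for the other measured compound, which leaves no numerical ranking of the two.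

The next compound is compound 3 `Cc1ccccc1-c1nc(CN2CCC(C(=O)NCCCN3CCCC(C(C)C)C3)CC2)c(C)o1` which has the same atoms as compound 2, joined differently. The change is this: a group of 9 heavy atoms (8 carbon, 1 nitrogen; one six-membered non-aromatic ring with 1 hetero atom) in place of a group of 9 heavy atoms (8 carbon, 1 nitrogen; one six-membered non-aromatic ring with 1 hetero atom), on a saturated chain carbon, three bonds along the chain from an amide-type nitrogen and it lies on a saturated chain carbon, three bonds along the chain from an amide-type nitrogen.

Within the data shown here, no measured step between compounds differing in one place is available. In this assay the expectation therefore rests on compound 2 with its limit of > 71 ug/mL and on the matching counts of the two groups. The expected move is an at least 1.0-fold lower number from compound 2 to compound 3 (0.00 log units; that floor lies within the scatter) and so none beyond the usual scatter. For compound 3 the estimate is 70 ug/mL with an expected range from 40 ug/mL to 85 ug/mL and a limit of the assay rather than an exact figure is considered likely.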

Compound 3, solubility: > 71 ug/mL
Compound 3 gave a limit, no number; the forecaster's own chance of this, stated with the estimate: 75%; at least 1.0-fold (0.00 log units) between middle value and limit.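

In this assay, among these compounds, compound 2 and compound 3 each give a limit of the assay rather than a number, so no step from one to the other can be read. Both stand at the same limit: the limit of > 71 ug/mL in this assay, at which 2 of the 3 values shown sit.

The compounds shown leave open whether replacing the 4-isopropylpiperidin-1-yl group with its rearranged counterpart changes the result in this assay at all, and in which direction.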